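A few compounds are considered here, and "the series" means these few. Any claim that something is new, unique, unknown or untested is made for them only; others in the source may bear on it.

Of the compounds shown here, three with a shared core have been measured in a functional assay on HCT-15 cells (Homo sapiens) for cytotoxicity, read by sulforhodamine B assay, with a stated time of 48 h, tested at 1 uM; on this read-out higher numbers stand for a weaker effect at the one concentration tested and lower numbers for a stronger effect. Compound 1, `COc1cc(C)cc(-c2nn(CC#N)cc2-c2ccc(-c3cccc(C(C)=O)c3)nc2)c1`, gives 12%. Compound 2, `Cc1cc(O)cc(-c2nn(CC#N)cc2-c2ccnc(-c3ccc(Oc4ccccc4)cc3)c2)c1`, gives -34%. Compound 3, `COc1cc(C)cc(-c2nn(CC#N)cc2-c2ccnc(-c3ccc(N(C)C)cc3)c2)c1`, gives -1%. Among these three numbers compound 3 stands second highest: its nearest neighbour is compound 1, whose number lies higher by a gap beyond the scatter, and its furthest is compound 2, whose number lies lower by a gap beyond the scatter.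

The next compound is compound 4, `Cc1cc(O)cc(-c2nn(CC#N)cc2-c2ccnc(-c3ccc(N(C)C)cc3)c2)c1`. Compared with compound 3 the change is hydrogen in place of methyl on an oxygen on an aromatic ring; cut one bond further out, it reads methoxy to hydroxy, or 3-methoxy-5-methylphenyl to 3-hydroxy-5-methylphenyl. Among the measured compounds shown here, no pair of measured compounds differs in exactly this one place, so the size of this step is not known from the data. Compound 2 carries the hydroxy form and gives the lowest of the three numbers, but it also differs elsewhere, so that comparison is only a hint.

The step from compound 3 to compound 4 is expected to be a number 11 percentage points lower from compound 3 to compound 4 (beyond the scatter) in this assay, a small move downward that may lie within the scatter. Compound 4 is estimated to give -12%, with a range from -40% to 15%.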

Compound 4, a percentage reported as activity, at one concentration (the size of the read-out at that concentration, not a potency): 14%
Compound 4: middle estimate off by 26 percentage points, on the low side; low and high end bracket the measured number.
By their numbers in this assay, from the lowest: compound 2; then compound 3; then compounds 1 and 4 (each within the scatter of the next).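

In this assay, among the compounds shown here, this position can now be read directly for the first time: a number 15 percentage points higher from compound 3 to compound 4 (beyond the scatter) shows that, with the dimethylamino group held fixed, hydroxy in place of methoxy weakens the effect rather than strengthening it. The hydroxy group alone therefore does not bring the low number of compound 2, and with hydroxy held fixed, dimethylamino in place of phenoxy gives a large step, a number 48 percentage points higher from compound 2 to compound 4 (beyond the scatter) in the same direction. No measurement available here explains either step.

The compounds shown leave open whether methoxy to hydroxy moves the number the same way when phenoxy is present rather than dimethylamino. They also leave open how an ethoxy group or an amino group would read in place of the hydroxy.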